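Working notes: solubility across a shared core

A few compounds are considered here, and "the series" means these few. Any claim that something is new, unique, unknown or untested is made for them only; others in the source may bear on it.

compound 1 `CC(C)Cc1ccc2c(NCCCNCc3ccco3)ccnc2c1` — 4200 nM
compound 2 `Fc1ccc(Cc2ccc3c(NCCCNCc4ccco4)ccnc3c2)c(Cl)c1` — 4200 nM

In a physicochemical assay for solubility, with a stated time of 18 h, at pH 7.4 (on this read-out higher numbers stand for higher solubility and lower numbers for lower solubility), compound 1 gives 4200 nM, and compound 2 gives 4200 nM. For the measured compounds named here, the single measured step, no change at the digits printed from compound 1 to compound 2 (within the scatter), left the read-out where it was, so compound 2 stands level with compound 1 on this assay. Compound 3 `COc1ccc(Oc2ccc3c(NCCCNCc4ccco4)ccnc3c2)cc1` differs from compound 2 by 4-methoxyphenoxy in place of 2-chloro-4-fluorobenzyl on an aromatic carbon. Going by the values given here, no measured step covers this exchange; the only step available, no change at the digits printed from compound 1 to compound 2 (within the scatter), swapped a different group at a different place and moved nothing. On that basis a step of about a 1.2-fold higher number from compound 2 to compound 3 (0.08 log units; within the scatter) is expected, not clearly beyond the scatter. Compound 3 is estimated at 5000 nM, with a range from 1500 nM to 16000 nM.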

Compound 3, solubility: 14500 nM
The estimate for compound 3 lay 2.9-fold (0.46 log units) below the measured number; the measured number falls inside the stated range.
By their numbers in this assay, from the lowest: compounds 1 and 2 (each within the scatter of the next); then compound 3.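

On an aromatic carbon of the shared core, the position responds to the group it carries in this assay: 4-methoxyphenoxy in place of 2-chloro-4-fluorobenzyl gives a 3.5-fold higher number from compound 2 to compound 3 (0.54 log units; beyond the scatter). The exchange for isobutyl gives the same size of step, a 3.5-fold higher number from compound 1 to compound 3 (0.54 log units; beyond the scatter), whereas isobutyl and 2-chloro-4-fluorobenzyl stand level. No supporting measurement bears on what lies behind this step.

On these data alone, the phenoxy link and the methoxy enter together in one exchange, so their separate shares remain open. As far as these compounds go, how an amine or a carboxylic acid at this position would read also remains open.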